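This account rests on a few compounds, and the source may have more. Where it says the series, first, only, none or still open, it means among the compounds named here.

Measured in a functional assay on MDA-MB-231 cells (Homo sapiens) for cytotoxicity, read by MTT assay, with a stated time of 48 h; on this read-out lower numbers stand for stronger inhibition and higher numbers for weaker inhibition:
- compound 1 `COc1ccccc1Nc1nc(-c2cccc(F)c2)nc2ccc(F)cc12`: > 50000 nM
- compound 2 `Nc1cccc(Nc2nc(-c3cccc(F)c3)nc3ccc(F)cc23)c1`: > 50000 nM
- compound 3 `Cc1ccc(Nc2nc(-c3cccc(F)c3)nc3ccc(F)cc23)cc1`: > 50000 nM

Compound 3 gives only a limit of the assay, > 50000 nM, not a number. The whole set offers one reading: the limit of > 50000 nM in this assay, at which 3 of the 3 values shown sit.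

Compound 4 `Cc1cccc(Nc2nc(-c3cccc(F)c3)nc3ccc(F)cc23)c1` carries 3-methylphenyl in place of 4-methylphenyl on a nitrogen on an aromatic ring, with the shared core unchanged: 3-methylphenyl in place of 4-methylphenyl on a nitrogen on an aromatic ring.

Two measured steps change the group at that same place: a step that the two limits leave unreadable from compound 1 to compound 3 and a step that the two limits leave unreadable from compound 2 to compound 3. Neither has a readable size, so they suggest no direction, and no step beyond the usual scatter is expected in this assay. The expected change is a number no higher from compound 3 to compound 4 (the limit leaves the size open). Compound 4 is estimated at 50000 nM, with an expected range from 15000 nM to 100000 nM, and the assay will probably report only a limit again.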

Compound 4, half-maximal inhibitory concentration: > 50000 nM
Compound 4: no number, only a limit; the forecaster's own chance of this, stated with the estimate: 80%; the middle value sits exactly at the limit.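

Compound 4 also gives only a limit, and its steps from compound 1, compound 2 and compound 3 cannot be read. The compounds shown leave open how strongly any of them acts in this assay, and whether the group on the nitrogen matters there at all.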